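Swapping an amide tail on a piperidine dopamine transporter ligand

The compounds below may be only part of what the source reports. "The series", "measured", "known", "first", "only" and "open" are said of these compounds alone.

Measured so far:
Compound 1 `Fc1ccc(C(SCCNC2CCN(Cc3ccccc3)CC2)c2ccc(F)cc2)cc1`: 32.9 nM
Compound 2 `O=C(c1cc2ccccc2[nH]1)N1CCC(NCCSC(c2ccc(F)cc2)c2ccc(F)cc2)CC1`: 177 nM
Compound 3 `CC(C)(C)C(=O)N1CCC(NCCSC(c2ccc(F)cc2)c2ccc(F)cc2)CC1`: 352 nM

These three compounds share one core and differ only in the group on the ring nitrogen. In an assay on membranes from striatum (strain Sprague-Dawley) for displacement of a labelled ligand from sodium-dependent dopamine transporter (Rattus norvegicus), read by scintillation counting, with a stated time of 120 min (on this read-out lower numbers stand for stronger inhibition and higher numbers for weaker inhibition), compound 3 stands furthest from compound 1, with an 11-fold higher number from compound 1 to compound 3 (1.03 log units; beyond the scatter); its gap to compound 2, a 2.0-fold higher number from compound 2 to compound 3 (0.30 log units; within the scatter), is within the scatter, so those two cannot be ranked against each other.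

Compound 4 `O=C(c1ccccc1F)N1CCC(NCCSC(c2ccc(F)cc2)c2ccc(F)cc2)CC1` is the next step: 2-fluorophenyl in place of tert-butyl on a carbonyl carbon. Among the measured compounds shown here, two measured steps bear on it. The move from a benzyl to a carbonyl-linked group is already paid for in an 11-fold higher number from compound 1 to compound 3 (1.03 log units; beyond the scatter) and a 5.4-fold higher number from compound 1 to compound 2 (0.73 log units; beyond the scatter). Among the carbonyl compounds, an aromatic ring against a tert-butyl made no difference beyond the scatter, as a 2.0-fold higher number from compound 2 to compound 3 (0.30 log units; within the scatter) shows. A 2-fluorophenyl on the carbonyl carbon is therefore expected to land close to compounds 2 and 3, with a step of about a 1.6-fold lower number from compound 3 to compound 4 (0.20 log units; within the scatter) expected in this assay. Compound 4 is estimated at 220 nM, within a range from 90 nM to 550 nM.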

Compound 4, inhibition constant: 46.1 nM
Estimate against measurement, compound 4: 4.8-fold (0.68 log units) above; measured number outside the range, below it.
By their numbers in this assay, from the lowest: compounds 1 and 4 (each within the scatter of the next); then compounds 2 and 3 (each within the scatter of the next).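

In this assay, the group on the carbonyl carbon turns out to matter: there is a 7.6-fold lower number from compound 3 to compound 4 (0.88 log units; beyond the scatter) and also a 3.8-fold lower number from compound 2 to compound 4 (0.58 log units; beyond the scatter) so the compounds with a carbonyl on the ring nitrogen do not all sit together, and having an aromatic ring there is not enough on its own, as compound 2 shows. Replacing benzyl with a carbonyl-linked group also need not weaken binding, since with a 1.4-fold higher number from compound 1 to compound 4 (0.15 log units; within the scatter) the two groups cannot be ranked against each other. Nothing measured here explains why 2-fluorophenyl stands apart from tert-butyl and 1H-indol-2-yl.

A plain phenyl on the carbonyl carbon would help show whether the fluorine matters or the six-membered ring does. As far as these compounds go, how an amine or a carboxylic acid on that ring would read also remains open.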